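Swapping One Aromatic Group on Compound 3

This account rests on a few compounds, and the source may have more. Where it says the series, first, only, none or still open, it means among the compounds named here.

In a physicochemical assay for solubility, read by spectrophotometry, measured as kinetic solubility, at pH 8, tested at 500 uM (on this read-out higher numbers stand for higher solubility and lower numbers for lower solubility), compound 1 (`Cn1ccc2ccc(-c3cc(Nc4ccccc4S(N)(=O)=O)cc4nccnc34)cc21`) gives 6 ug/mL while compound 2 (`CN1CC(NC(=O)c2ccncc2Nc2cc(-c3ccc4ccn(C)c4c3)c3nccnc3c2)CCC1=O`) gives 253 ug/mL and compound 3 (`CN1CCC(NC(=O)c2ccncc2Nc2cc(-c3ccc4sc(N)nc4c3)c3nccnc3c2)C1`) gives 241 ug/mL as its reading. Compound 3 therefore sits level with compound 2 within the usual scatter of repeat measurements, and far from compound 1.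

Compound 4 (`CN1CCC(NC(=O)c2ccncc2Nc2cc(-c3cc(F)c4ccn(C)c4c3)c3nccnc3c2)C1`) keeps the rest of compound 3 but puts 4-fluoro-1-methyl-1H-indol-6-yl in place of 2-amino-1,3-benzothiazol-5-yl on an aromatic carbon. Going by the values given here, no measured pair shows this swap directly, so the neighbours must serve as a guide. Compound 2 carries the same indole group without the fluorine and still gives 253 ug/mL as its reading. Compound 1 also has that group, yet it gives 6 ug/mL and lacks the amide arm found in compounds 2, 3 and 4.

The estimated change is small, with an expected 1.1-fold lower number from compound 3 to compound 4 (0.05 log units; within the scatter) in this assay and no large move foreseen. For compound 4 the estimate is 215 ug/mL with an expected range from 100 ug/mL to 270 ug/mL in this measurement.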

Compound 4, solubility: 185 ug/mL
Beside the measured number, compound 4's estimate is 1.2-fold (0.07 log units) above it, and the stated range covers the measured number.
By their numbers in this assay, from the lowest: compound 1; then compounds 4, 3 and 2 (each within the scatter of the next).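

In this assay the swap of 2-amino-1,3-benzothiazol-5-yl for 4-fluoro-1-methyl-1H-indol-6-yl gives a 1.3-fold lower number from compound 3 to compound 4 (0.11 log units; within the scatter) and so shows that this position, on an aromatic carbon of a six-membered aromatic ring of carbon only, accepts this exchange with no reading that can be told apart from the starting one. The group that leaves has 1 hydrogen-bond donor and 3 hydrogen-bond acceptors, the group that enters has 0 hydrogen-bond donors and 1 hydrogen-bond acceptor, and this difference in counts comes with no move beyond the scatter. Nothing measured here explains why the two readings stay level.

Still open, as far as these compounds go, is what the fluorine or the amino group contributes on its own. From the compounds shown here alone, whether a morpholine or a carboxylic acid in this place would keep the reading level also remains unknown.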